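Pentafluorophenyl sulfonyl variant of the flavone series

This account rests on a few compounds, and the source may have more. Where it says the series, first, only, none or still open, it means among the compounds named here.

Compound 1 `COc1ccc(-c2cc(=O)c3c(OC)cc(OC)cc3n2S(=O)(=O)c2ccc(F)cc2)cc1` carries a 4-fluorophenyl on the sulfonyl sulfur. In a functional assay on HepG2 cells (Homo sapiens) for antiproliferative activity, with a stated time of 72 h (on this read-out lower numbers stand for an effect already at smaller amounts and higher numbers for an effect only at larger amounts of compound), compound 1 gives only a limit, > 65500 nM. Compound 2 `COc1ccc(-c2cc(=O)c3c(OC)cc(OC)cc3n2S(=O)(=O)c2cc(F)c(F)c(F)c2)cc1` carries a 3,4,5-trifluorophenyl in its place. In this assay compound 2 likewise gives only a limit, > 65500 nM. The step that the two limits leave unreadable from compound 1 to compound 2 therefore cannot be read in size or direction; both values sit at the limit of > 65500 nM in this assay, at which 2 of the 2 values shown sit, and compound 2 stands at that limit with no number of its own.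

Compound 3 `COc1ccc(-c2cc(=O)c3c(OC)cc(OC)cc3n2S(=O)(=O)c2c(F)c(F)c(F)c(F)c2F)cc1` differs from compound 2 by 2,3,4,5,6-pentafluorophenyl in place of 3,4,5-trifluorophenyl on a sulfonyl sulfur, that is, two more fluorine atoms on the same ring that is attached to the sulfonyl sulfur next to the aromatic nitrogen of the shared core. Only the unreadable step from compound 1 to compound 2 bears on this change, so no step size beyond the scatter can be derived in this assay, in either direction. The expectation for compound 3 is that it again stays at the limit, estimated as 65500 nM within 20000 nM to 200000 nM, which would mean an expected step of a number no higher from compound 2 to compound 3 (the limit leaves the size open).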

Compound 3, half-maximal effective concentration: > 34400 nM
Compound 3 ended at the assay's limit; the forecaster's own chance of this, stated with the estimate: 85%; the middle value lies beyond the limit too.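

In this assay compound 3 gives > 34400 nM, a limit and not a number. Going by these compounds alone, with compound 1 and compound 2 also only at limits, no step among compound 1, compound 2 and compound 3 can be read in size or direction. Left open is whether the number of fluorine atoms on the ring on the sulfonyl sulfur changes the read-out in this assay at all.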